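Swapping an Aromatic Ring for a Saturated One

A few compounds are considered here, and "the series" means these few. Any claim that something is new, unique, unknown or untested is made for them only; others in the source may bear on it.

Of the compounds shown here, three of one shared core have been tested in a functional assay on the whole organism (strain CF-1 albino) with Mus musculus as the target, with a stated time of 4 h; a higher number here means that more compound is needed for the effect, a lower number that less compound is needed. Compound 2 `O=C1CC(c2ccccc2Br)C(=O)N1CN1CCN(c2ccc(F)cc2)CC1` gives 100 mg/kg, and compound 3 `O=C1CC(c2ccccc2Br)C(=O)N1CN1CCN(c2cccc(Cl)c2)CC1` gives 100 mg/kg; these two are level, and together they give the lowest numbers of the three. Compound 1 `O=C1CC(c2ccccc2F)C(=O)N1CN1CCN(c2ccccc2)CC1` gives 300 mg/kg, a higher dose. Among the compounds with values here, the only single-point step recorded, no change at the digits printed from compound 2 to compound 3 (within the scatter), lies within the scatter. Compound 4 `O=C1CC(c2ccccc2Br)C(=O)N1CN1CCN(C2CCCCC2)CC1` is not yet measured; it differs from compound 2 by cyclohexyl in place of 4-fluorophenyl on an amine nitrogen in a ring. Within the data shown here, no measured step tests an aromatic-to-non-aromatic exchange on the ring nitrogen, so the expectation leans on the flat step from compound 2 to compound 3 and allows for a modest rise. Compound 4 is therefore estimated at 150 mg/kg, between 60 mg/kg and 400 mg/kg, an expected step of a 1.5-fold higher number from compound 2 to compound 4 (0.18 log units; within the scatter).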

Compound 4, minimum effective dose: 100 mg/kg
For compound 4 the middle estimate is 1.5-fold (0.18 log units) above the measured one, within the range that was stated.
By their numbers in this assay, from the lowest: compounds 2, 3 and 4 (each within the scatter of the next); then compound 1.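

In this assay, the ring on this nitrogen need not be aromatic: cyclohexyl in place of 4-fluorophenyl gives (no change at the digits printed from compound 2 to compound 4 (within the scatter)), and cyclohexyl in place of 3-chlorophenyl gives (no change at the digits printed from compound 3 to compound 4 (within the scatter)). Among these three compounds, then, neither the aromatic ring nor its halogen is needed to keep the printed dose. Nothing here explains why the exchange leaves the dose level. On these data alone, whether this tolerance extends to a methyl group, a longer alkyl chain or a chain ending in a carboxylic acid on this nitrogen remains open.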